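Swapping fluoro for methoxy on the aryl ring of compound 2

The source may hold more compounds than are shown below. What is called first, only, known or untested is meant among the compounds shown, and "the series" means these compounds.

Measured so far:
compound 1 `CCC(CC)c1ccc2c(NCCCNCc3cc(F)ccc3OC)ccnc2c1` gives 4200 nM
compound 2 `COc1ccc(F)cc1CNCCCNc1ccnc2cc(-c3ccc(F)cc3)ccc12` gives 32000 nM

Among the measured compounds shown here, in a physicochemical assay for solubility, with a stated time of 18 h, at pH 7.4 (on this read-out higher numbers stand for higher solubility and lower numbers for lower solubility), compound 2 stands highest of the two numbers; the one step seen so far, a 7.6-fold higher number from compound 1 to compound 2 (0.88 log units; beyond the scatter), came with 4-fluorophenyl in place of pentan-3-yl. Compound 3 `COc1ccc(-c2ccc3c(NCCCNCc4cc(F)ccc4OC)ccnc3c2)cc1` differs from compound 2 by methoxy in place of fluoro on an aromatic carbon. For the measured compounds named here, no measured step bears on this change, since the only one on record concerns a different part of the structure. Compound 3 is therefore expected to give a number close to that of compound 2, with a step of a 1.3-fold lower number from compound 2 to compound 3 (0.11 log units; within the scatter) that is expected to stay within the scatter, at about 25000 nM, between 8000 nM and 80000 nM.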

Compound 3, solubility: 32000 nM
Compound 3: middle estimate off by 1.3-fold (0.11 log units), on the low side; the measured number falls inside the stated range.
By their numbers in this assay, from the lowest: compound 1; then compounds 2 and 3 (each within the scatter of the next).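

In this assay, changing 4-fluorophenyl to 4-methoxyphenyl at this place gives no change at the digits printed from compound 2 to compound 3 (within the scatter) and so does not separate the fluoro and methoxy groups. Replacing pentan-3-yl with 4-methoxyphenyl gives a 7.6-fold higher number from compound 1 to compound 3 (0.88 log units; beyond the scatter) and matches the direction of the step seen with 4-fluorophenyl, so this rise does not depend on the fluoro group. No measurement on hand explains either result. From the compounds shown here alone, whether an amine or a carboxylic acid at this place on the phenyl ring would give a similar number remains open.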